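Chain-shortened nitrile analogues of a tetrabrominated core

This account rests on a few compounds, and the source may have more. Where it says the series, first, only, none or still open, it means among the compounds named here.

Measured compounds:
compound 1 `Cc1nc2c(Br)c(Br)c(Br)c(Br)c2n1CC#N` gives 45%
compound 2 `Cc1nc2c(Br)c(Br)c(Br)c(Br)c2n1CCC#N` gives 84%
compound 3 `N#CCCCCn1cnc2c(Br)c(Br)c(Br)c(Br)c21` gives 98%

All three were run in a functional assay on CCRF-CEM cells (Homo sapiens) for cytotoxicity, read by MTT assay, with a stated time of 24 h, tested at 10 uM; on this read-out higher numbers stand for a weaker effect at the one concentration tested and lower numbers for a stronger effect. Compound 1 and compound 2 share a core that carries a methyl on the ring; compound 3 carries a longer chain on a core without that methyl, and the difference between the two cores is not broken down here.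

Within the pair with the shared core, the step is cyano in place of cyanomethyl on a saturated chain carbon bound to an aromatic nitrogen, and it is large: a number 39 percentage points lower from compound 2 to compound 1 (beyond the scatter). Compound 3 stands with the highest number of the three, that is, the weakest effect at the concentration tested.

Compound 4 `N#CCCCn1cnc2c(Br)c(Br)c(Br)c(Br)c21` is not yet measured. The change from compound 3 to compound 4 is cyano in place of cyanomethyl on a saturated chain carbon, three bonds along the chain from an aromatic nitrogen. Within the data shown here, this is the same kind of change as the one from compound 2 to compound 1, but not the same: there the place was on a saturated chain carbon bound to an aromatic nitrogen, here it is on a saturated chain carbon three bonds along the chain from an aromatic nitrogen. The earlier step was a large drop in the number. Among the measured compounds shown here, for compound 4 a smaller step is expected, a number 8 percentage points lower from compound 3 to compound 4 (within the scatter), resting on the one step from compound 2 to compound 1 and on compound 2, which is the nearest measured chain length and gives 84%. Compound 4 is estimated at 90%, with a range from 78% to 100%.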

Compound 4, a percentage reported as activity, at one concentration (the size of the read-out at that concentration, not a potency): 85%
The estimate for compound 4 lay 5 percentage points above the measured number; low and high end bracket the measured number.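

In this assay, the change from cyanomethyl to cyano on the core without the methyl gives a number 13 percentage points lower from compound 3 to compound 4 (beyond the scatter), so the number falls in the same direction as on the core with the methyl. The size of the step does not carry over from one core to the other: the same change on two cores in this assay, a number 39 percentage points lower (beyond the scatter) from compound 2 to compound 1 and a number 13 percentage points lower (beyond the scatter) from compound 3 to compound 4, 26 percentage points apart, beyond the scatter of two such steps This does not show what sets the size, as the two steps differ both in the core and in the place of the change, on a saturated chain carbon bound to an aromatic nitrogen in one and three bonds along the chain from an aromatic nitrogen in the other, and two steps make no rule for the series.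

Still open, going by these compounds, is how the step from 3-cyanopropyl to 2-cyanoethyl, or from 2-cyanoethyl to cyanomethyl, reads on the core without the methyl, since the same cut on that core would separate the effect of the core from that of the chain length. Also open, on these data alone, is what an amine or a carboxylic acid in place of the nitrile, or a chain longer than 4-cyanobutyl, would give on either core.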